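Amide nitrogen substituent and liver clearance in the series

The source may hold more compounds than are shown below. What is called first, only, known or untested is meant among the compounds shown, and "the series" means these compounds.

Working notes on three measured compounds and one awaiting measurement. The shared core is seen in compound 1 `CSc1nc2cc(Cl)ccc2o1`, which in an ADME assay on microsomes from liver (Homo sapiens) for metabolic stability, read by LC-MS, using NADPH, with a stated time of 45 min, tested at 0.5 uM (a lower number here means slower removal, a higher number faster removal of the compound), gives 19 mL/min/g. Compound 2 `CC1CCN(C(=O)CCSc2nc3cc(Cl)ccc3o2)C1` carries an amide on the chain and in this assay gives 10.1 mL/min/g. Compound 3 `CN(C(=O)CCSc1nc2cc(Cl)ccc2o1)C1CCS(=O)(=O)C1` in this assay gives 1.5 mL/min/g, the lowest of the three numbers; its gap to compound 2 and to compound 1 lies beyond the usual scatter in each case.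

Compound 4 `CN(C)C(=O)CCSc1nc2cc(Cl)ccc2o1` is not yet measured. It differs from compound 3 in one place: methyl in place of 1,1-dioxothiolan-3-yl on an amide-type nitrogen. Within the data shown here, no measured pair in the set isolates this exact change, so the expectation rests on the values of compound 3 and compound 2 only.

The step from compound 3 to compound 4 is expected to be upward and beyond the scatter, a 4.0-fold higher number from compound 3 to compound 4 (0.60 log units; beyond the scatter), because compound 2 gives 10.1 mL/min/g with a smaller group on the amide-type nitrogen. For compound 4 the estimated value in this assay is 6 mL/min/g, with a range from 2.5 mL/min/g to 15 mL/min/g.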

Compound 4, intrinsic clearance in a liver preparation (reported as CLH), per the amount of preparation that the assay uses: 2.7 mL/min/g
The estimate for compound 4 lay 2.2-fold (0.35 log units) above the measured number; the range from low to high includes it.
By their numbers in this assay, from the lowest: compounds 3 and 4 (each within the scatter of the next); then compounds 2 and 1 (each within the scatter of the next).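

In this assay, methyl in place of 1,1-dioxothiolan-3-yl on the amide-type nitrogen gives a 1.8-fold higher number from compound 3 to compound 4 (0.26 log units; within the scatter), so the low number of compound 3 does not depend on keeping that seven-heavy-atom ring; the much smaller methyl serves as well within the scatter. The step that does exceed the scatter at this amide is on the carbonyl carbon, where dimethylamino in place of 3-methylpyrrolidin-1-yl gives a 3.7-fold lower number from compound 2 to compound 4 (0.57 log units; beyond the scatter). Against the core of compound 1, (dimethylcarbamoyl)methyl in place of hydrogen on a saturated chain carbon bound to a sulfur gives a 7.0-fold lower number from compound 1 to compound 4 (0.85 log units; beyond the scatter), so the dimethylamide chain on its own accounts for a step beyond the scatter.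

From the compounds shown here alone, what an ethyl or 2-hydroxyethyl group on the amide-type nitrogen, or a longer chain, would give in this assay stays open. Nothing available here explains any of these steps.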